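The compounds below may be only part of what the source reports. "The series", "measured", "known", "first", "only" and "open" are said of these compounds alone.

Compound 1, with the structure `N=C(N)N/N=C/c1c(-c2cccs2)nc2n1CCS2`, was examined in a functional assay on cells (Melanoma cell, Homo sapiens) for inhibition (on this read-out lower numbers stand for stronger inhibition of growth and higher numbers for weaker inhibition of growth), and gave 21400 nM. Among the three compounds measured so far, compound 1 has the highest number. Compound 2, `N=C(N)N/N=C/c1c(-c2ccsc2)nc2sccn12`, gave 17000 nM in this assay, a value that lies within the scatter of compound 1. Compound 3, `Cc1cn2c(/C=N/NC(=N)N)c(-c3cccs3)nc2s1`, gave 2240 nM in this assay, a step below compound 1 that lies beyond the scatter.

From compound 1 the account turns to compound 4, `N=C(N)N/N=C/c1c(-c2cc(Cl)sc2Cl)nc2n1CCS2`, which has not yet been measured in this assay. The change is 2,5-dichlorothiophen-3-yl in place of thiophen-2-yl on an aromatic carbon. For the measured compounds named here, no pair of measured compounds shows this change on its own, so no measured step is available as a guide; compounds 1 and 2 carry different cores as well as different thiophene attachments and cannot isolate it.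

The expectation for compound 4 in this assay is a modest move toward a lower number, a 1.8-fold lower number from compound 1 to compound 4 (0.25 log units; within the scatter), which may still fall within the scatter. Compound 4 is therefore estimated at 12000 nM, with a range from 4000 nM to 40000 nM.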

Compound 4, concentration for 50% growth inhibition: 10000 nM
Compound 4: middle estimate off by 1.2-fold (0.08 log units), on the high side, within the range that was stated.
By their numbers in this assay, from the lowest: compound 3; then compounds 4, 2 and 1 (each within the scatter of the next, the first and the last beyond it).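

For the compounds shown here, putting 2,5-dichlorothiophen-3-yl in place of thiophen-2-yl gives the first step in this set that changes only one place, and it is a modest one (a 2.1-fold lower number from compound 1 to compound 4 (0.33 log units; beyond the scatter)) in this assay. It shows that this aromatic carbon, next to the ring nitrogen, can carry the group with two chlorine atoms and keep growth inhibition, with a small gain that lies beyond the scatter. The data offer no measured explanation for this step.

The change moves the thiophene attachment and adds both chlorine atoms at once, so the part played by each stays unresolved. Also open, as far as these compounds go, are how a simple thiophen-3-yl, a monochlorothiophene or a phenyl ring would behave here, and whether the same exchange would give a similar step on the core of compound 3.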